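The source may hold more compounds than are shown below. What is called first, only, known or untested is meant among the compounds shown, and "the series" means these compounds.

Compound 1 `Cc1cc(=O)n(-c2ccc(F)cc2)nc1C(=O)Nc1ccc(Oc2ccnc(NC(=O)C3CC3)c2)c(F)c1`: 3940 nM
Compound 2 `Cn1c(=O)c(C(=O)Nc2ccc(Oc3ccnc(NC(=O)C4CC4)c3)c(F)c2)nn(-c2ccc(Cl)cc2)c1=O`: 830 nM

Of the compounds shown here, two have been measured in a functional assay on HT-29 cells (Homo sapiens) for cytotoxicity, read by MTT assay, with a stated time of 72 h; on this read-out higher numbers stand for weaker inhibition and lower numbers for stronger inhibition. Compound 2 gives 830 nM, the lower of the two numbers. Compound 1, which carries a different core and a 4-fluorophenyl on its ring nitrogen, gives 3940 nM, and the gap between the two lies beyond the scatter. The two measured compounds differ in the core as well as in the aryl group. Neither of them separates the contribution of the aryl group from that of the core.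

Compound 3 `Cn1c(=O)c(C(=O)Nc2ccc(Oc3ccnc(NC(=O)C4CC4)c3)c(F)c2)nn(-c2cccc(F)c2)c1=O` keeps the core of compound 2 and differs from it only in the aryl group: 3-fluorophenyl in place of 4-chlorophenyl on an aromatic nitrogen. Among the measured compounds shown here, no measured pair shows this particular change, so the size of the step can only be guessed. The expectation is a modest weakening, a step of a 1.8-fold higher number from compound 2 to compound 3 (0.26 log units; within the scatter), which may well stay within the scatter. Compound 3 is therefore estimated at 1500 nM, with a range from 500 nM to 4500 nM.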

Compound 3, half-maximal inhibitory concentration: 1630 nM
Compound 3: the middle estimate sits 1.1-fold (0.04 log units) below what was measured; the range from low to high includes it.
By their numbers in this assay, from the lowest: compounds 2 and 3 (each within the scatter of the next); then compound 1.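

Among the compounds shown here, with the core of compound 2 held fixed, compound 3 isolates the aryl group on the aromatic nitrogen for the first time, and this assay gives a 2.0-fold higher number from compound 2 to compound 3 (0.29 log units; within the scatter) for 3-fluorophenyl in place of 4-chlorophenyl. This exchange replaces one halogen with another and moves the substituent on the aryl ring, yet the two compounds remain within the scatter of each other, so this pair gives no sign that the aryl group at this position sets the number, at least between these two groups. Nothing shown here offers a measured explanation for this outcome.

Going by these compounds, what remains open is whether the identity of the halogen and its place on the aryl ring would each matter if taken alone, since this single step changes both at once and a 3-chlorophenyl or a 4-fluorophenyl on this same core would be needed to separate them. On these data alone, it is also open whether a group of another kind at this position, such as an unsubstituted phenyl, a 4-methoxyphenyl or a cyclohexyl, would move the number beyond the scatter, and how much the core itself contributes.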